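The compounds below may be only part of what the source reports. "The series", "measured", "known", "first", "only" and "open" are said of these compounds alone.

In a functional assay on MDA-MB-231 cells (Homo sapiens) for antiproliferative activity, read by MTT assay, with a stated time of 24 h (on this read-out lower numbers stand for stronger inhibition and higher numbers for weaker inhibition), compound 1 (`O=C(O)CC(NC(=O)c1ccc(Cl)cc1Cl)c1ccccc1`) gives 67200 nM and compound 2 (`CC(C)(C)c1ccc(C(CC(=O)O)NC(=O)c2ccc(Cl)cc2Cl)cc1`) gives 67800 nM, so the two cannot be told apart. Compound 3 (`O=C(O)CC(NC(=O)c1ccc(Cl)cc1Cl)c1ccccc1F`) differs from compound 1 by fluoro in place of hydrogen on an aromatic carbon, which is fluoro in place of hydrogen on an aromatic carbon, ortho to a large group. Within the data shown here, the only measured step, a 1.0-fold higher number from compound 1 to compound 2 (0.00 log units; within the scatter), puts tert-butyl in place of hydrogen on an aromatic carbon. What is therefore expected in this assay is no change beyond the scatter, an estimated 1.1-fold lower number from compound 1 to compound 3 (0.03 log units; within the scatter). For compound 3 the expected value is 62000 nM, with an estimated range of 28000 nM to 125000 nM.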

Compound 3, half-maximal inhibitory concentration: 89300 nM
Estimate against measurement, compound 3: 1.4-fold (0.16 log units) below, within the range that was stated.
By their numbers in this assay, from the lowest: compounds 1, 2 and 3 (each within the scatter of the next).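

In this assay fluoro in place of hydrogen on an aromatic carbon, ortho to a large group, gives a 1.3-fold higher number from compound 1 to compound 3 (0.12 log units; within the scatter) and thus stays within the scatter. This shows that the small fluoro at this position, like the tert-butyl of compound 2, does not separate its compound from compound 1 on this read-out. Nothing available explains this result.

The compounds shown leave open whether an amine or a methoxy group at this same position would give a step beyond the scatter. They also leave open whether any change on this ring would do so.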